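The compounds below may be only part of what the source reports. "The series", "measured", "known", "first", "only" and "open" are said of these compounds alone.

Of the compounds shown here, three have so far been measured in a functional assay on BV-2 cells (Mus musculus), with stated times of 2 h and 24 h, tested at 10 uM; a lower number here means a stronger effect, a higher number a weaker effect of the compound at the concentration tested. Compound 1 `O=C(CCc1ccc(O)cc1)C[C@@H]1O[C@@H](c2ccc(O)cc2)[C@H]2[C@@H]1[C@H](c1ccc(O)cc1)O[C@H]2CC(=O)CCc1ccc(O)cc1` gives 87.8% in this assay. Compound 2 `COc1cc([C@@H]2O[C@@H](CC(=O)CCc3ccc(O)cc3)[C@@H]3[C@H]2[C@H](CC(=O)CCc2ccc(O)cc2)O[C@H]3c2ccc(O)cc2)ccc1O` differs from compound 1 in a single place: methoxy in place of hydrogen on an aromatic carbon. In this assay compound 2 gives 86.8%, so the two numbers cannot be told apart.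

Compound 3 `Oc1ccc(CC[C@@H](O)C[C@H](O)CCc2ccc(O)cc2)cc1` is built on a different core; the difference between its core and the core of compound 1 is not broken down here. In this assay compound 3 gives 94.8%, a number that lies within the scatter of the numbers for compound 1 and compound 2, so no order among the three can be claimed from these data.

Compound 4 `COc1cc(CC[C@@H](O)C[C@H](O)CCc2ccc(O)cc2)ccc1O` has not yet been measured. It stands to compound 3 exactly as compound 2 stands to compound 1: methoxy in place of hydrogen on an aromatic carbon. The surroundings of the changed carbon are described in the same words for both pairs, so this is the same change, carried onto the other core. Among the compounds with values here, only one earlier example of it exists, and it sits on a core that is not the core of compound 3, so the expectation rests on a single data point. A step of about a number 0.8 percentage points lower from compound 3 to compound 4 (within the scatter) is expected from compound 3 to compound 4 because the same change earlier gave a number 1 percentage points lower from compound 1 to compound 2 (within the scatter). Compound 4 is therefore estimated to give about 94% in this assay, most likely between 86% and 100%.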

Compound 4, a percentage reported as activity, at one concentration (the size of the read-out at that concentration, not a potency): 85.7%
Estimate against measurement, compound 4: 8.3 percentage points above; measured number below the stated range.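

In this assay, within the data shown here, methoxy in place of hydrogen on this aromatic carbon, ortho to a hydroxy group, gives a number 9.1 percentage points lower from compound 3 to compound 4 (within the scatter), so on this core too the change produces no step that can be told apart from the usual spread of repeated measurements. Set beside the earlier example, the two steps cannot be told apart either: the same change on two cores in this assay, a number 1 percentage points lower (within the scatter) from compound 1 to compound 2 and a number 9.1 percentage points lower (within the scatter) from compound 3 to compound 4, 8.1 percentage points apart, within the scatter of two such steps This shows that the results on the two cores are compatible with one another, but it does not show that the change has the same effect on both, and with only two small and uncertain steps, a real dependence on the core can be neither seen nor ruled out.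

The compounds shown carry only hydrogen or methoxy on this carbon, so it remains open what an ethoxy group, a fluorine atom or an amine would do there in this assay. Also open, on these data alone, is whether a carboxylic acid in place of the hydroxy group on the same ring would give a step that stands clear of the scatter, and whether methoxy would behave the same way on any further core.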